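This account rests on a few compounds, and the source may have more. Where it says the series, first, only, none or still open, it means among the compounds named here.

Compound 1 `O=C(Nc1ccc(Cl)cc1CN1C(=O)c2ccccc2C1=O)c1ccccc1`: < 1000 nM
Compound 2 `O=C(Nc1ccc(Cl)cc1CN1C(=O)c2ccccc2C1=O)c1ncccc1O`: < 1000 nM

In an assay on CHO cells for positive allosteric modulation of metabotropic glutamate receptor 5 (Rattus norvegicus), read by FLIPR (a higher number here means that more compound is needed for the effect, a lower number that less compound is needed), compound 1 gives < 1000 nM, which is a limit of the assay rather than a number. In this assay compound 2 likewise gives < 1000 nM, again only a limit. Both values shown sit at the limit of < 1000 nM in this assay, at which 2 of the 2 values shown sit. The step that the two limits leave unreadable from compound 1 to compound 2 is therefore of unreadable size. Compound 3 `O=C(Nc1ccc(Cl)cc1CN1C(=O)c2ccccc2C1=O)c1cccnn1` differs from compound 2 by pyridazin-3-yl in place of 3-hydroxypyridin-2-yl on a carbonyl carbon. Among the compounds with values here, no measured step of readable size bears on this change, so neither direction nor size can be drawn from the numbers. The step that the limit leaves unreadable from compound 2 to compound 3 is expected to stay within the scatter. Compound 3 is thus estimated at 500 nM, with a range from 100 nM to 2500 nM.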

Compound 3, half-maximal effective concentration: < 1000 nM
Compound 3: a limit, no number; the forecaster's own chance of this, stated with the estimate: 55%; the middle value does not contradict the limit.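

No step between compound 1, compound 2 and compound 3 can be read, since each value is only a limit and not a number: the limit of < 1000 nM in this assay, at which 3 of the 3 values shown sit.

On these data alone, whether phenyl, 3-hydroxypyridin-2-yl and pyridazin-3-yl on the carbonyl carbon differ at all in this assay remains open.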